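A Fluorine Swap on the Benzylamide of Compound 2

The source may report more compounds than this note shows. Statements on the series, on what has been measured and on what is new or still open speak of the compounds shown alone.

Measured so far:
compound 1, `CC(=O)c1nc([N+](=O)[O-])c(Sc2c(Cl)cncc2Cl)s1`: 670 nM
compound 2, `Cc1ccc(CNC(=O)c2nc([N+](=O)[O-])c(Sc3c(Cl)cncc3Cl)s2)cc1`: 3650 nM

In an assay on isolated protein for inhibition of ubiquitin carboxyl-terminal hydrolase 7 (Homo sapiens), read by fluorescence, with stated times of 30 min and 3 h (a higher number here means a weaker inhibitor, a lower number a stronger inhibitor), compound 1 gives 670 nM, and compound 2 gives 3650 nM. Going by the values given here, compound 2 therefore stands highest of the two numbers, with compound 1 as its only neighbour. Among the compounds with values here, the single measured step, a 5.4-fold higher number from compound 1 to compound 2 (0.74 log units; beyond the scatter), concerns the group on the carbonyl carbon and is the only comparison available.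

Compound 3, `O=C(NCc1cccc(F)c1)c1nc([N+](=O)[O-])c(Sc2c(Cl)cncc2Cl)s1`, differs from compound 2 by 3-fluorophenyl in place of 4-methylphenyl on a saturated chain carbon bound to an amide-type nitrogen. Within the data shown here, no measured step touches this part of the molecule, so nothing among the numbers speaks for or against a shift in this assay. Compound 3 is expected to land close to compound 2, with an estimated step of a 1.1-fold lower number from compound 2 to compound 3 (0.06 log units; within the scatter), not beyond the scatter. Compound 3 is estimated at 3200 nM, within a range of 1200 nM to 8500 nM.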

Compound 3, half-maximal inhibitory concentration: 1350 nM
Beside the measured number, compound 3's estimate is 2.4-fold (0.37 log units) above it; measured number inside the range.
By their numbers in this assay, from the lowest: compounds 1 and 3 (each within the scatter of the next); then compound 2.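

In this assay, the aromatic ring of the benzylamide proves sensitive to substitution: 3-fluorophenyl in place of 4-methylphenyl gives a 2.7-fold lower number from compound 2 to compound 3 (0.43 log units; beyond the scatter) (a modest step). The amide is therefore not tied to the whole of the earlier change from methyl on the carbonyl carbon, a 5.4-fold higher number from compound 1 to compound 2 (0.74 log units; beyond the scatter), since the 3-fluorobenzyl version gives a 2.0-fold higher number from compound 1 to compound 3 (0.30 log units; within the scatter) and so stays level with compound 1. No measurement here offers a reason for the shift.

The swap removes the methyl and adds the fluorine in one move, so the compounds shown cannot say which of the two carries the step, and a plain phenyl on that chain carbon would bear on this. Also open, from the compounds shown here alone, is how a longer chain between the amide nitrogen and the ring, or an amine on the ring, would read in this assay.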